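Dropping One Fluoro at the Assay Limit

The source may report more compounds than this note shows. Statements on the series, on what has been measured and on what is new or still open speak of the compounds shown alone.

Compound 1 `O=C(Nc1ccc(F)cc1)c1cc(=O)[nH]c2cc(Br)ccc12`: > 20000 nM
Compound 2 `O=C(Nc1cc(F)ccc1F)c1cc(=O)[nH]c2cc(Br)ccc12`: > 20000 nM

Both compounds were tested in a functional assay on KYSE-70 cells for antiproliferative activity against KYSE-70 cell line (Homo sapiens), read by MTT assay, with a stated time of 72 h; on this read-out lower numbers stand for stronger inhibition and higher numbers for weaker inhibition. Compound 2 stands at > 20000 nM, which is a limit of the assay and not a number. Compound 1 gives > 20000 nM, which is also a limit. So far, the data show (the limit of > 20000 nM in this assay, at which 2 of the 2 values shown sit).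

Compound 3 `O=C(Nc1cccc(F)c1)c1cc(=O)[nH]c2cc(Br)ccc12` differs from compound 2 in one place: hydrogen in place of fluoro on an aromatic carbon. Hydrogen replaces fluoro on an aromatic carbon, ortho to a large group and para to a fluoro group.

Among the measured compounds shown here, no measured step shows what such a change does in this assay. Since compound 2 sits at > 20000 nM, no change beyond the scatter is expected. The expected step that the limit leaves unreadable from compound 2 to compound 3 is therefore small. For compound 3 the estimate is 25000 nM, with an expected range of 10000 nM to 50000 nM.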

Compound 3, half-maximal inhibitory concentration: 8900 nM
Estimate against measurement, compound 3: 2.8-fold (0.45 log units) above; measured number below the stated range.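

In this assay, hydrogen in place of fluoro on an aromatic carbon, ortho to a large group and para to a fluoro group, gives an at least 2.2-fold lower number from compound 2 to compound 3 (0.35 log units; beyond the scatter), so this position responds to a change in a way that compound 1 and compound 2 alone could not show. Having 3-fluorophenyl in place of 4-fluorophenyl on the amide-type nitrogen gives an at least 2.2-fold lower number from compound 1 to compound 3 (0.35 log units; beyond the scatter), so where a single fluoro sits on this ring also matters here. Both steps give only a smallest size, because each one starts from a limit: the limit of > 20000 nM in this assay, at which 2 of the 3 values shown sit.

What the compounds shown leave open is whether the fluoro remaining in compound 3 adds anything to its activity. Also open, going by these compounds, is how a larger or different group, such as chloro, methoxy or an amine, would behave on this ring.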